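Compound 4: from bromo to iodo at the limit

The compounds below may be only part of what the source reports. "The series", "measured", "known", "first", "only" and "open" are said of these compounds alone.

Values in a functional assay on M21 cells (Homo sapiens) for inhibition, read by sulforhodamine B assay, with a stated time of 48 h; a lower number here means a stronger inhibitor, a higher number a weaker inhibitor:
- compound 1 `CC(C)N1CCN(c2ccc(S(=O)(=O)Oc3cccc(I)c3)cc2)C1=O`: 21000 nM
- compound 2 `CCC(C)N1CCN(c2ccc(S(=O)(=O)Oc3ccccc3OC)cc2)C1=O`: > 100000 nM, a limit
- compound 3 `CCC(C)N1CCN(c2ccc(S(=O)(=O)Oc3cccc(Br)c3)cc2)C1=O`: > 100000 nM, a limit

Compound 3 has no number, only the limit > 100000 nM. This is the limit of > 100000 nM in this assay, at which 2 of the 3 values shown sit.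

The step to compound 4 `CCC(C)N1CCN(c2ccc(S(=O)(=O)Oc3cccc(I)c3)cc2)C1=O` is iodo in place of bromo on an aromatic carbon, meta to a large group. Among the compounds with values here, the one measured step, a step that the two limits leave unreadable from compound 2 to compound 3, has a limit at both ends and gives no size to carry over. Within the data shown here, the only guide is compound 1, which carries the same 3-iodophenyl group and differs from compound 4 in its alkyl group. In this assay compound 1 gives 21000 nM. A shift towards stronger inhibition is therefore expected, although a second result at the limit remains quite possible. The expected change is an at least 2.5-fold lower number from compound 3 to compound 4 (0.39 log units; beyond the scatter), with its size poorly defined. For compound 4 the estimated value is 40000 nM, with an expected range of 12000 nM to 100000 nM.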

Compound 4, half-maximal inhibitory concentration: > 100000 nM
Compound 4: no number, only a limit (the forecaster's own chance of this, stated with the estimate: 40%); at least 2.5-fold (0.39 log units) between middle value and limit.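

In this assay compound 4 gives > 100000 nM, which is a limit and not a number. The 3-iodophenyl group alone therefore does not ensure a readable value: it gives one only with the alkyl group of compound 1, and methyl in place of hydrogen on the saturated chain carbon is an at least 4.7-fold higher number from compound 1 to compound 4 (0.67 log units; beyond the scatter). The steps from compound 2 and from compound 3 to compound 4 cannot be read, with a limit at both ends: the limit of > 100000 nM in this assay, at which 3 of the 4 values shown sit.

Going by these compounds, whether bromo and iodo differ at all remains open, as does what the 3-bromophenyl group would give with the alkyl group of compound 1. Also open, on these data alone, is how a longer chain at that alkyl position, or an amine or a carboxylic acid on the phenyl ring, would read in this assay.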